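The compounds below may be only part of what the source reports. "The series", "measured", "known", "first", "only" and "open" are said of these compounds alone.

Measured so far in an assay for binding affinity to Alpha-1D adrenergic receptor (Homo sapiens), read by radioligand binding; on this read-out lower numbers stand for stronger inhibition and higher numbers for weaker inhibition:
- compound 1, `CSc1ccc(C)cc1NCC1=NCCN1`: 17.4 nM
- compound 2, `Cc1ccc(S(C)(=O)=O)c(NCC2=NCCN2)c1`: 4790 nM
- compound 3, `CS(=O)(=O)c1cc(F)ccc1NCC1=NCCN1`: 1620 nM

Compound 1 gives the lowest number of the three in this assay; compound 3 and compound 2 sit far higher. Among the compounds with values here, the one single-point step recorded, a 280-fold higher number from compound 1 to compound 2 (2.44 log units; beyond the scatter), concerns the sulfur group and does not bear on the change considered here. Compound 4, `CSc1ccc(F)cc1NCC1=NCCN1`, differs from compound 1 by fluoro in place of methyl on an aromatic carbon. Within the data shown here, no measured pair isolates this swap, so the step is set by analogy to a small substituent exchange: a step in this assay of no more than the usual scatter is expected, with a slight lean to a higher number. The estimate for compound 4 is therefore 25 nM, range 8 nM to 80 nM, meaning an expected 1.4-fold higher number from compound 1 to compound 4 (0.16 log units; within the scatter).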

Compound 4, inhibition constant: 6.17 nM
Beside the measured number, compound 4's estimate is 4.1-fold (0.61 log units) above it, outside the stated range (below it).
By their numbers in this assay, from the lowest: compound 4; then compound 1; then compound 3; then compound 2.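

In this assay, the position para to a methylsulfanyl group responds to a one-atom exchange: fluoro in place of methyl gives a 2.8-fold lower number from compound 1 to compound 4 (0.45 log units; beyond the scatter). The methyl is therefore not required for a low number in this series, and this change moves the number down rather than up. Nothing at hand accounts for the direction of this step. The compounds shown leave open whether chloro, methoxy or an amine at this position would lower the number further or raise it.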